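Swapping the aryl group on the shared core: stability outlook

The compounds below may be only part of what the source reports. "The series", "measured", "known", "first", "only" and "open" are said of these compounds alone.

Compound 1 `Cc1oc(-c2c(Cl)cccc2Cl)nc1CN1CCC(C(=O)NCCCN2C[C@H](C)C[C@H](C)C2)CC1`: 0.0483 h
Compound 2 `Cc1ccccc1-c1nc(CN2CCC(C(=O)NCCCN3CCCC(C(C)C)C3)CC2)c(C)o1`: 0.323 h

In an ADME assay on microsomes from liver (Rattus norvegicus) for metabolic stability, read by LC-MS, using NADPH, at 37 degrees C (a lower number here means that the compound disappears faster, a higher number that the compound lasts longer), compound 1 gives 0.0483 h, the lowest of the two numbers shown. For the measured compounds named here, compound 2 gives 0.323 h, a higher number that lies beyond the usual scatter; with no single-point step between these two, nothing more can be read from that pair.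

Compound 3 `COc1cccc(F)c1-c1nc(CN2CCC(C(=O)NCCCN3C[C@H](C)C[C@H](C)C3)CC2)c(C)o1` has not yet been measured in this assay. It differs from compound 1 in one place: 2-fluoro-6-methoxyphenyl in place of 2,6-dichlorophenyl on an aromatic carbon. Going by the values given here, no measured step for this kind of change exists here, so the expectation rests on compound 1 alone. The half-life of compound 3 is expected to stay close to that of compound 1, with a step from compound 1 to compound 3 of a 1.2-fold higher number from compound 1 to compound 3 (0.09 log units; within the scatter), a small shift, if any, within the scatter. Compound 3 is therefore estimated at 0.06 h, in a range from 0.025 h to 0.15 h.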

Compound 3, half-life: 0.143 h
Estimate against measurement, compound 3: 2.4-fold (0.38 log units) below; measured number inside the range.
By their numbers in this assay, from the lowest: compound 1; then compound 3; then compound 2.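

For the compounds shown here, this is the first step that can be read at this position, on an aromatic carbon of the five-membered aromatic ring, and it shows that the aryl group there can shift the half-life in this assay. Placing 2-fluoro-6-methoxyphenyl where 2,6-dichlorophenyl stood gives a 3.0-fold higher number from compound 1 to compound 3 (0.47 log units; beyond the scatter) on an otherwise unchanged structure, so this swap alone accounts for the difference. Nothing available here establishes why the half-life shifts with this change.

On these data alone, both chlorine atoms leave in this one step, so it remains open whether the fluorine or the methoxy group matters more. A phenyl ring bearing one chlorine and one methoxy group, or one bearing an amine, could help separate these contributions and show how far the trend extends.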